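The compounds below may be only part of what the source reports. "The series", "measured", "known", "first", "only" and "open" are said of these compounds alone.

Measured in a functional assay on A549 cells (Homo sapiens) for inhibition, read by MTT assay, with a stated time of 72 h; a lower number here means a stronger inhibitor, a higher number a weaker inhibitor:
compound 1 `O=C(NNC(=O)C1CC1c1ccc(OC(F)(F)F)cc1)c1ccncc1`, 56000 nM
compound 2 `COc1ccc(C2CC2C(=O)NNc2nncc3ccccc23)cc1`, 96000 nM
compound 3 `O=C(NNc1nncc2ccccc12)C1CC1c1ccc(OC(F)(F)F)cc1`, 87000 nM

Compound 1 gives the lowest of the three numbers in this assay, yet its gaps to compound 3 and to compound 2 both lie within the scatter, so no order among the three can be read. Compound 4 `COc1ccc(C2CC2C(=O)NNC(=O)c2ccncc2)cc1`, not yet measured, differs from compound 1 by methyl in place of trifluoromethyl on an oxygen on an aromatic ring. Among the compounds with values here, the only measured step at this position runs the other way, on the core shared by compound 2 and compound 3: a 1.1-fold lower number from compound 2 to compound 3 (0.04 log units; within the scatter). Taking that step in reverse, no change beyond the scatter is expected from compound 1 to compound 4, the expected step being a 1.1-fold higher number from compound 1 to compound 4 (0.03 log units; within the scatter). Compound 4 is therefore estimated at 60000 nM, with a range of 25000 nM to 140000 nM.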

Compound 4, half-maximal inhibitory concentration: > 100000 nM
Compound 4 gave a limit, no number (the forecaster's own chance of this, stated with the estimate: 10%); middle value at least 1.6-fold (0.22 log units) away from the limit.
By their numbers in this assay, from the lowest: compounds 1, 3 and 2 (each within the scatter of the next). At a limit, above all of these: compound 4.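

In this assay compound 4 gives a limit (> 100000 nM) and no number. Trifluoromethoxy to methoxy at this position therefore reads only as a floor (an at least 1.7-fold higher number from compound 1 to compound 4 (0.25 log units; that floor lies within the scatter)), so this change on the core of compound 1 cannot be shown to go beyond the scatter. Whether the change acts alike on both cores also stays unsettled: the same change on two cores in this assay, a 1.1-fold lower number (0.04 log units; within the scatter) from compound 2 to compound 3 and an at least 1.7-fold lower number (0.25 log units; that floor lies within the scatter) from compound 4 to compound 1; the limit leaves it open whether they differ

On these data alone, the size of the step beyond that floor remains open. So does the effect of a hydroxyl or an amine in place of trifluoromethoxy on the aromatic ring.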